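The source may report more compounds than this note shows. Statements on the series, on what has been measured and on what is new or still open speak of the compounds shown alone.

Compound 1 `C=C[C@@H]1C[C@@H](Cc2ccc(OC)c(O)c2)[C@H]2C(=O)C=CC(=C)[C@H]21`: 0.4 nM
Compound 2 `C=C1C=CC(=O)[C@@H]2[C@H](Cc3ccc(F)c(F)c3)CC[C@H]12`: 222 nM
Compound 3 `C=C1C=CC(=O)[C@@H]2[C@H](Cc3ccc(OC)c(F)c3)CC[C@H]12`: 1.68 nM

All three values come from a functional assay on A-375 cells (Homo sapiens) for antiproliferative activity, with a stated time of 72 h; on this read-out higher numbers stand for weaker inhibition and lower numbers for stronger inhibition. Compound 3, at 1.68 nM, holds the second highest of the three numbers, above compound 1 and below compound 2.

Compound 4 `C=C1C=CC(=O)[C@@H]2[C@H](Cc3ccc(OC)c(O)c3)CC[C@H]12` has not yet been measured. It differs from compound 3 in one place: hydroxy in place of fluoro on an aromatic carbon, ortho to a methoxy group (hydroxy in place of fluoro on an aromatic carbon).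

Within the data shown here, only one measured step bears directly on this change: a 130-fold lower number from compound 2 to compound 3 (2.12 log units; beyond the scatter), a large step in which methoxy took the place of fluoro on an aromatic carbon. It also removes a fluoro, but a different group enters, so its size cannot simply be carried over. Compound 1, at 0.4 nM, carries the same hydroxy and methoxy groups on its aromatic ring as compound 4, although it also differs from compound 4 elsewhere. Its value therefore points towards a lower number in this assay, and a modest step is expected rather than a large one. The expected change is a 2.1-fold lower number from compound 3 to compound 4 (0.32 log units; beyond the scatter). For compound 4 the estimated value is 0.8 nM, with an expected range from 0.2 nM to 3.5 nM.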

Compound 4, half-maximal inhibitory concentration: 1.07 nM
Beside the measured number, compound 4's estimate is 1.3-fold (0.13 log units) below it; the measured number falls inside the stated range.
By their numbers in this assay, from the lowest: compound 1; then compounds 4 and 3 (each within the scatter of the next); then compound 2.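

In this assay, hydroxy in place of fluoro on the aromatic carbon ortho to a methoxy group gives a 1.6-fold lower number from compound 3 to compound 4 (0.20 log units; within the scatter), so with the methoxy group in place, these two groups cannot be told apart at this position, unlike the large step seen when methoxy replaced fluoro in a 130-fold lower number from compound 2 to compound 3 (2.12 log units; beyond the scatter). With the hydroxy and methoxy groups held constant on the aromatic ring, the change that does go beyond the scatter lies on the saturated ring, where hydrogen in place of vinyl gives a 2.7-fold higher number from compound 1 to compound 4 (0.43 log units; beyond the scatter). Nothing measured here accounts for either of these steps.

On these data alone, whether an amine or a carboxylic acid on the same aromatic carbon would read alike with fluoro and hydroxy remains open, as does the effect of a bare hydrogen there. Also open, as far as these compounds go, is whether vinyl on the saturated ring carbon would shift the number by a similar amount with fluoro on the aromatic ring, and what a longer chain in place of that vinyl would do.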